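The source may hold more compounds than are shown below. What is called first, only, known or untested is meant among the compounds shown, and "the series" means these compounds.

Compound 1 `Cc1nc(-c2cccnc2)sc1-c1nnc(-c2ccc(Br)cc2)o1`. In an ADME assay on HeLa cells (Homo sapiens) for cytotoxicity, read by MTT assay (a higher number here means that more compound is tolerated, a lower number that less compound is tolerated), compound 1 gives > 100 ug/mL, which is a limit of the assay rather than a number.
Compound 2 `Cc1nc(-c2cccnc2)sc1-c1nnc(-c2ccc(Cl)cc2)o1`. In this assay compound 2 gives > 100 ug/mL, again a limit.
Compound 3 `Cc1cccc(-c2nnc(-c3sc(-c4cccnc4)nc3C)o2)c1`. In this assay compound 3 gives > 100 ug/mL, also a limit.

Compound 3 therefore stands where every measured compound here stands: at the limit of > 100 ug/mL in this assay, at which 3 of the 3 values shown sit. For the measured compounds named here, no compound in this set has produced a number, so no ordering among them can be read.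

Compound 4 `Cc1nc(-c2cccnc2)sc1-c1nnc(-c2cccnc2)o1` is not yet measured. The change from compound 3 to compound 4 is pyridin-3-yl in place of 3-methylphenyl on an aromatic carbon. The measured steps that touch the same position are a step that the two limits leave unreadable from compound 1 to compound 3 and a step that the two limits leave unreadable from compound 2 to compound 3; the remaining step, a step that the two limits leave unreadable from compound 1 to compound 2, is likewise unreadable. In each case both ends sit at the limit, so none of them shows what swapping the group at this position does to tolerated concentration.

Given that three swaps at this position all left the compounds at the limit, compound 4 is expected to behave the same way, and the step that the limit leaves unreadable from compound 3 to compound 4 is estimated to be nothing beyond the scatter. For compound 4 the expected value in this assay is 150 ug/mL, with a range from 60 ug/mL to 400 ug/mL, most likely reported again only as a limit.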

Compound 4, half-maximal cytotoxic concentration: > 100 ug/mL
Compound 4: a limit, no number; the forecaster's own chance of this, stated with the estimate: 80%; the middle value is on the limit's open side.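

In this assay compound 4 gives > 100 ug/mL, which is a limit and not a number. The steps to compound 4 from compound 1, compound 2 and compound 3 therefore cannot be read: the limit of > 100 ug/mL in this assay, at which 4 of the 4 values shown sit. The compounds shown leave open at what concentration any of the four stops being tolerated, and whether swapping this group changes that concentration.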